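The source may report more compounds than this note shows. Statements on the series, on what has been measured and on what is new or still open speak of the compounds shown alone.

- compound 1 `Cc1cc(C(F)(F)F)c2cccc(OCc3c(Cl)ccc(S(=O)(=O)N4CCC[C@H]4CO)c3Cl)c2n1` with 250 mL/min/kg measured
- compound 2 `Cc1cc(C(F)(F)F)c2cccc(OCc3c(Cl)ccc(S(=O)(=O)N4CC[C@@H](N(C)C)C4)c3Cl)c2n1` with 167 mL/min/kg measured

In an ADME assay on microsomes (Homo sapiens) for metabolic stability (on this read-out lower numbers stand for slow clearance and higher numbers for fast clearance), compound 2 stands at 167 mL/min/kg and so within the usual scatter of compound 1. Compound 3 `Cc1cc(C(F)(F)F)c2cccc(OCc3c(Cl)ccc(S(=O)(=O)N4CCCCC4)c3Cl)c2n1` has not been measured. It carries piperidin-1-yl in place of 3-(dimethylamino)pyrrolidin-1-yl on a sulfonyl sulfur. Going by the values given here, the only measured step at that place (a 1.5-fold lower number from compound 1 to compound 2 (0.18 log units; within the scatter)) stays within the scatter, so no step beyond the scatter is expected in this assay here. The expected step is small (a 1.1-fold higher number from compound 2 to compound 3 (0.06 log units; within the scatter)). For compound 3 the estimated value is 190 mL/min/kg with an expected range to match (90 mL/min/kg to 350 mL/min/kg).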

Compound 3, clearance: 233 mL/min/kg
For compound 3 the middle estimate is 1.2-fold (0.09 log units) below the measured one; the range from low to high includes it.
By their numbers in this assay, from the lowest: compounds 2, 3 and 1 (each within the scatter of the next).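

In this assay, the plain piperidin-1-yl ring on the sulfonyl sulfur stays within the scatter of both substituted pyrrolidines: the data give a 1.4-fold higher number from compound 2 to compound 3 (0.14 log units; within the scatter) and a 1.1-fold lower number from compound 1 to compound 3 (0.03 log units; within the scatter). Neither the dimethylamino nor the hydroxymethyl group therefore separates from the unsubstituted ring at this place, so all three sulfonyl substituents remain indistinguishable on this read-out. Nothing available explains this outcome. From the compounds shown here alone, it remains open whether a carboxylic acid or a morpholine on the sulfonyl sulfur would give a step beyond the scatter, or whether a change elsewhere on the shared core would do so.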